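This account rests on a few compounds, and the source may have more. Where it says the series, first, only, none or still open, it means among the compounds named here.

Measured so far in an ADME assay on cells (Homo sapiens) for cytotoxicity, read by polymerase chain reaction, with a stated time of 3 days; a higher number here means that more compound is tolerated, a lower number that less compound is tolerated:
compound 1 `CCNc1nc(C)c(-c2nc3ccccc3s2)c(N[C@@H]2C[C@H](CO)[C@@H](O)[C@H]2O)n1` gives 12000 nM
compound 2 `Cc1nc(NC(C)(C)C)nc(N[C@@H]2C[C@H](CO)[C@@H](O)[C@H]2O)c1-c1nc2ccccc2s1` gives 12000 nM
compound 3 `Cc1nc(NCCOC(C)C)nc(N[C@@H]2C[C@H](CO)[C@@H](O)[C@H]2O)c1-c1nc2ccccc2s1` gives 8000 nM

All three share one core and differ only in the group carried on a nitrogen on an aromatic ring. Compound 3 gives the lowest of the three numbers, but its gap to compound 1 and to compound 2 is within the scatter, so no ordering among them is claimed.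

Compound 4 `Cc1nc(NCCNS(C)(=O)=O)nc(N[C@@H]2C[C@H](CO)[C@@H](O)[C@H]2O)c1-c1nc2ccccc2s1` has not yet been measured in this assay. It differs from compound 3 by methanesulfonamido in place of isopropoxy on a saturated chain carbon, two bonds along the chain from a nitrogen on an aromatic ring.

For the measured compounds named here, none of the measured steps introduces a methanesulfonamido group, so no step bears directly on this change. The steps that do exist all vary the same substituent on the same nitrogen: no change at the digits printed from compound 1 to compound 2 (within the scatter); a 1.5-fold lower number from compound 1 to compound 3 (0.18 log units; within the scatter); a 1.5-fold lower number from compound 2 to compound 3 (0.18 log units; within the scatter). Each of them is within the scatter, so across ethyl, tert-butyl and 2-isopropoxyethyl this assay has not moved beyond its noise.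

On that basis the step of a 1.3-fold higher number from compound 3 to compound 4 (0.10 log units; within the scatter) is expected to stay within the scatter, with no direction favoured. Compound 4 is therefore estimated at 10000 nM in this assay, with a range from 5000 nM to 24000 nM.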

Compound 4, half-maximal cytotoxic concentration: > 25000 nM
Compound 4: no number, only a limit (the forecaster's own chance of this, stated with the estimate: 15%); at least 2.5-fold (0.39 log units) between middle value and limit.
By their numbers in this assay, from the lowest: compounds 3, 1 and 2 (each within the scatter of the next). At a limit, above all of these: compound 4.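

In this assay compound 4 gives no number, only a limit: the limit of > 25000 nM in this assay, at which 1 of the 4 values shown sits. Even read from that limit, the substituent on this nitrogen now moves the assay beyond the scatter, which ethyl, tert-butyl and 2-isopropoxyethyl did not do among themselves: the steps are an at least 3.1-fold higher number from compound 3 to compound 4 (0.49 log units; beyond the scatter) and an at least 2.0-fold higher number from compound 2 to compound 4 (0.31 log units; beyond the scatter) and an at least 2.0-fold higher number from compound 1 to compound 4 (0.31 log units; beyond the scatter) on the same shared core. The sharpest comparison is the one-place change from isopropoxy to methanesulfonamido on a saturated chain carbon, two bonds along the chain from a nitrogen on an aromatic ring, so this position can shift the tolerated concentration, and in this series only methanesulfonamido has done so.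

Going by these compounds, how far compound 4 lies past its limit stays unknown, so all three steps give only a lower bound on size. Which part of methanesulfonamido goes with the higher number also stays open: an acetamido group, an amine or a carboxylic acid at the same place, or a longer chain carrying the methanesulfonamido group, would be needed to separate the possibilities.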